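The compounds below may be only part of what the source reports. "The series", "measured", "known", "first", "only" and "open" are said of these compounds alone.

Compound 1 `Cc1cccc(/C=C2\SC(=S)N(NS(=O)(=O)c3ccccc3)C2=O)c1` gives > 50000 nM in a functional assay on ECV-304 cells (Homo sapiens) for cytotoxicity (on this read-out lower numbers stand for stronger inhibition and higher numbers for weaker inhibition), which is a limit of the assay and not a number.
Compound 2 `O=C1/C(=C/c2ccccc2F)SC(=S)N1NS(=O)(=O)c1ccccc1` gives > 50000 nM in this assay, again only a limit.
Compound 3 `O=C1/C(=C/c2ccc(Cl)c(Cl)c2)SC(=S)N1NS(=O)(=O)c1ccccc1` gives > 50000 nM in this assay, again only a limit.

Compound 1 therefore stands at the limit of > 50000 nM in this assay, at which 3 of the 3 values shown sit, together with every other measured value. Compound 4 `Cc1ccc(/C=C2\SC(=S)N(NS(=O)(=O)c3ccccc3)C2=O)cc1C` differs from it by methyl in place of hydrogen on an aromatic carbon. The measured steps from compound 1 are a step that the two limits leave unreadable from compound 1 to compound 2 and a step that the two limits leave unreadable from compound 1 to compound 3, so neither gives a readable size or direction for changing the group on that chain carbon. With no readable step to build on, the expected step is a number no higher from compound 1 to compound 4 (the limit leaves the size open), most likely again ending at the limit. Compound 4 is accordingly estimated at 50000 nM, within 15000 nM to 100000 nM.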

Compound 4, half-maximal inhibitory concentration: > 50000 nM
Compound 4 gave a limit, no number; the forecaster's own chance of this, stated with the estimate: 85%; the middle value sits exactly at the limit.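

Compound 4 gives only a limit, so no step can be read among compound 1, compound 2, compound 3 and compound 4: the limit of > 50000 nM in this assay, at which 4 of the 4 values shown sit.

The compounds shown leave open whether changing the group on that chain carbon alters the result in this assay at all.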